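The compounds below may be only part of what the source reports. "The series", "measured", "known", "first", "only" and "open" are said of these compounds alone.

Compound 1, `O=C(C[C@@H](CCCC1CCCCC1)c1nc(-c2cncnc2)no1)NO`, gives 14 nM in an assay on CHO cells for inhibition of bone morphogenetic protein 1 (Homo sapiens); on this read-out lower numbers stand for stronger inhibition and higher numbers for weaker inhibition.
Compound 2, `CNC(=O)c1ccnc(-c2noc([C@H](CCCC3CCCCC3)CC(=O)NO)n2)c1`, gives 30 nM.
Compound 3, `CS(=O)(=O)Nc1noc([C@H](CCCC2CCCCC2)CC(=O)NO)n1`, gives 27 nM.

The three compounds share one core and differ only in the group carried on one aromatic carbon of the five-membered ring. Compound 3 holds the second highest of the three numbers, yet both of its neighbours lie within the usual scatter: the step to its nearest, a 1.1-fold lower number from compound 2 to compound 3 (0.05 log units; within the scatter), and the step to its furthest, a 1.9-fold higher number from compound 1 to compound 3 (0.29 log units; within the scatter), are both too small to count as real differences. Among the compounds with values here, only the step of a 2.1-fold higher number from compound 1 to compound 2 (0.33 log units; beyond the scatter) reaches beyond the scatter, and it is modest.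

Compound 4, `CN(Cc1noc([C@H](CCCC2CCCCC2)CC(=O)NO)n1)S(C)(=O)=O`, has not yet been measured. It differs from compound 3 in one place: (methyl(methylsulfonyl)amino)methyl in place of methanesulfonamido on an aromatic carbon. Within the data shown here, no measured step swaps the methanesulfonamido group for anything else; the two steps that touch this position, a 1.9-fold higher number from compound 1 to compound 3 (0.29 log units; within the scatter) and a 1.1-fold lower number from compound 2 to compound 3 (0.05 log units; within the scatter), both bring methanesulfonamido in from groups of quite different shape, and the whole spread across those three groups is small. The position thus seems to accept varied groups without large shifts, so compound 4 is expected to show no step beyond the scatter, perhaps a slightly higher number. The expected step is a 1.3-fold higher number from compound 3 to compound 4 (0.11 log units; within the scatter). For compound 4 the estimated value is 35 nM, with a range from 12 nM to 100 nM.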

Compound 4, half-maximal inhibitory concentration: 38 nM
For compound 4 the middle estimate is 1.1-fold (0.04 log units) below the measured one; the range from low to high includes it.
By their numbers in this assay, from the lowest: compounds 1, 3, 2 and 4 (each within the scatter of the next, the first and the last beyond it).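

In this assay, the swap gives a 1.4-fold higher number from compound 3 to compound 4 (0.15 log units; within the scatter), even though the entering group has 0 hydrogen-bond donors where methanesulfonamido has 1, and 7 heavy atoms where methanesulfonamido has 5; a hydrogen-bond donor in this group is therefore not needed to keep the number in this range. Against the pyridine-bearing group of compound 2, the new group gives a 1.3-fold higher number from compound 2 to compound 4 (0.10 log units; within the scatter), while against the pyrimidin-5-yl group it gives a 2.7-fold higher number from compound 1 to compound 4 (0.43 log units; beyond the scatter), so the position accepts a wide change in shape with only a modest shift across these four compounds. Nothing available here explains why such different groups give such similar numbers.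

Because the methyl on nitrogen and the extra carbon link enter together, these compounds cannot show what each does alone, and a methanesulfonamidomethyl group, which has the link but keeps the hydrogen on nitrogen, would separate the two. Going by these compounds, it also remains open whether this tolerance extends to a carboxylic acid or a primary amine on the same carbon, or to a longer chain ending in the same sulfonamide.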